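This account rests on a few compounds, and the source may have more. Where it says the series, first, only, none or still open, it means among the compounds named here.

Measured compounds: compound 1 `Cn1ncc2c(-c3ccc(F)cc3)cc(NNC(=O)Nc3cc(Cl)nc(OCCF)c3)nc21`, 2790 nM; compound 2 `CCCc1cc(NNC(=O)Nc2cc(Cl)nc(Cl)c2)nc2c1cnn2C`, 1400 nM; compound 3 `Cn1ncc2c(-c3ccc(F)cc3)cc(NNC(=O)Nc3cc(F)cc(F)c3)nc21`, 3980 nM.

In an assay on isolated protein for binding affinity to sphingosine 1-phosphate receptor 2 (Homo sapiens), read by surface plasmon resonance (on this read-out higher numbers stand for weaker binding and lower numbers for tighter binding), compound 1 gives 2790 nM, the second highest of the measured numbers; compound 3 is its nearest neighbour and compound 2 its furthest, and both gaps stay within the scatter. The unmeasured compound 4 `CCCCOc1cc(NC(=O)NNc2cc(-c3ccc(F)cc3)c3cnn(C)c3n2)cc(Cl)n1` shows ethyl in place of fluoro on a saturated chain carbon, two bonds along the chain from an oxygen on an aromatic ring relative to compound 1. For the measured compounds named here, the only measured single step, a 1.4-fold higher number from compound 1 to compound 3 (0.15 log units; within the scatter), alters a different part of the molecule and stays within the scatter, while no measured step touches the 2-fluoroethoxy chain itself, and compound 2 cannot be paired with compound 1 in one step. It is therefore expected that compound 4 shows no step beyond the scatter in this assay, the estimated change being a 1.0-fold higher number from compound 1 to compound 4 (0.00 log units; within the scatter). Compound 4 is expected to give 2800 nM, with a range from 1000 nM to 8000 nM.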

Compound 4, dissociation constant: 2650 nM
Compound 4: middle estimate off by 1.1-fold (0.02 log units), on the high side; the measured number falls inside the stated range.
By their numbers in this assay, from the lowest: compounds 2, 4, 1 and 3 (each within the scatter of the next, the first and the last beyond it).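

In this assay, butoxy in place of 2-fluoroethoxy gives a 1.1-fold lower number from compound 1 to compound 4 (0.02 log units; within the scatter), the only measured step on this chain among the compounds shown. At this place, on a saturated chain carbon, two bonds along the chain from an oxygen on an aromatic ring, the read-out therefore does not separate ethyl from fluoro. From the compounds shown here alone, whether a chain carrying an amine or a carboxylic acid, or one longer than butoxy, would read the same stays open, as does whether any group here can move the number beyond the scatter. Nothing shown bears on why these two chains read alike.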